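The source may hold more compounds than are shown below. What is called first, only, known or untested is meant among the compounds shown, and "the series" means these compounds.

Compounds measured in a functional assay on MDA-MB-231 cells (Homo sapiens) for inhibition, read by sulforhodamine B assay, with a stated time of 48 h; a higher number here means a weaker inhibitor of growth, a lower number a stronger inhibitor of growth:

compound 1 `COc1cc(-c2cc(/C=C/C(=O)c3ccc(N)cc3)[nH]n2)cc(OC)c1OC`, 2060 nM
compound 2 `COc1cc(-c2cc(/C=C/C(=O)c3ccc(Cl)c(Cl)c3)[nH]n2)cc(OC)c1OC`, 8650 nM
compound 3 `COc1ccc(-c2cc(/C=C/C(=O)c3ccc(N)cc3)[nH]n2)cc1OC`, 4420 nM

Compound 2 stands highest of the three numbers in this assay. Its nearest neighbour is compound 3, a gap within the scatter, so no order between those two is claimed; compound 1 is furthest from it, beyond the scatter.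

The next compound, compound 4 `COc1ccc(C(=O)/C=C/c2cc(-c3cc(OC)c(OC)c(OC)c3)n[nH]2)cc1`, differs from compound 2 as follows: 4-methoxyphenyl in place of 3,4-dichlorophenyl on a carbonyl carbon. The measured step that bears on this change is the one made at the same carbonyl carbon, a 4.2-fold higher number from compound 1 to compound 2 (0.62 log units; beyond the scatter), a modest rise on moving from 4-aminophenyl to 3,4-dichlorophenyl. The other step, a 2.1-fold higher number from compound 1 to compound 3 (0.33 log units; beyond the scatter), concerns a methoxy on an aromatic carbon of the other aryl group and is less directly relevant. For the measured compounds named here, no measured compound carries 4-methoxyphenyl at the carbonyl carbon, so the direction must be read from the reverse of the step from compound 1 to compound 2: leaving 3,4-dichlorophenyl is expected to lower the number, while how much of the ground between compound 2 and compound 1 a methoxy group recovers is uncertain. Compound 4 is therefore expected to give 3000 nM in this assay, with a range of 1200 nM to 8000 nM. The expected step is a 2.9-fold lower number from compound 2 to compound 4 (0.46 log units; beyond the scatter).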

Compound 4, concentration for 50% growth inhibition: 1880 nM
Estimate against measurement, compound 4: 1.6-fold (0.20 log units) above; the range from low to high includes it.
By their numbers in this assay, from the lowest: compounds 4 and 1 (each within the scatter of the next); then compounds 3 and 2 (each within the scatter of the next).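

Working from this assay, the carbonyl carbon now shows that replacing 3,4-dichlorophenyl with 4-methoxyphenyl gives a 4.6-fold lower number from compound 2 to compound 4 (0.66 log units; beyond the scatter), so the earlier rise seen in a 4.2-fold higher number from compound 1 to compound 2 (0.62 log units; beyond the scatter) is no longer tied to 4-aminophenyl as the sole comparator. The change from amino to methoxy on the aromatic carbon gives a 1.1-fold lower number from compound 1 to compound 4 (0.04 log units; within the scatter), which lies within the scatter, so this assay does not separate 4-aminophenyl from 4-methoxyphenyl at this place; among the three aryl groups shown on the carbonyl carbon, only 3,4-dichlorophenyl stands apart, with a number beyond the scatter of both others. The data offer no measured basis for explaining this difference.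

The compounds shown leave open where unsubstituted phenyl, a phenyl bearing a single chlorine, or a phenyl bearing a carboxylic acid would fall on the carbonyl carbon, and so whether the higher number belongs to the chlorines themselves or to their number. For the compounds shown here, also open is whether the step of a 2.1-fold higher number from compound 1 to compound 3 (0.33 log units; beyond the scatter), seen only with 4-aminophenyl on the carbonyl carbon, would recur with 4-methoxyphenyl there.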